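The compounds below may be only part of what the source reports. "The series", "measured", "known", "first", "only" and "open" are said of these compounds alone.

Series notes, step from compound 2 to compound 4.

Compound 2 `COc1cc(NC(=O)Nc2cc(Nc3cc(Br)ccc3OC)ncn2)cc(OC)c1` gives 43.5% in a functional assay on NCI-H520 cells (Homo sapiens) for inhibition, read by MTT assay, with a stated time of 48 h, tested at 10 uM; on this read-out lower numbers stand for less inhibition and higher numbers for more inhibition at the one concentration tested (going by the name of the read-out). Among the three numbers so far it stands second highest: compound 1 `COc1ccc(Br)cc1Nc1cc(NC(=O)Nc2c(Cl)cccc2Cl)ncn1` lies nearest with 45%, a gap within the scatter, and compound 3 `COc1ccc(C(F)(F)F)cc1Nc1cc(NC(=O)Nc2c(Cl)cccc2Cl)ncn1` lies furthest with 33%, a gap beyond the scatter.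

Compound 4 `COc1cc(NC(=O)Nc2cc(Nc3ccc(F)c(Cl)c3)ncn2)cc(OC)c1` is not yet measured. It differs from compound 2 at the nitrogen on the aromatic ring whose other neighbour is an aromatic carbon: 3-chloro-4-fluorophenyl in place of 5-bromo-2-methoxyphenyl on a nitrogen on an aromatic ring.

Two steps are in hand. The step of a number 1.5 percentage points lower from compound 1 to compound 2 (within the scatter) concerns the aryl on the amide-type nitrogen, not the ring changed here, and shows that side tolerating a swap without a shift beyond the scatter. The step of a number 12 percentage points lower from compound 1 to compound 3 (beyond the scatter) concerns the ring that is changed here, and a single substituent exchange on it already brought a modest drop beyond the scatter. The present change is larger, removing both the bromo and the methoxy and bringing in chloro and fluoro, so a drop of similar or somewhat larger size is expected in this assay, though a result within the scatter cannot be excluded.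

Compound 4 is therefore expected to give about 32%, between 18% and 46%, corresponding to an expected step of a number 11.5 percentage points lower from compound 2 to compound 4 (beyond the scatter).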

Compound 4, a percentage reported as inhibition, at one concentration (the size of the read-out at that concentration, not a potency): 25.5%
Compound 4: the middle estimate sits 6.5 percentage points above what was measured, within the range that was stated.
By their numbers in this assay, from the lowest: compounds 4 and 3 (each within the scatter of the next); then compounds 2 and 1 (each within the scatter of the next).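

In this assay, 3-chloro-4-fluorophenyl in place of 5-bromo-2-methoxyphenyl on the nitrogen on the aromatic ring gives a number 18 percentage points lower from compound 2 to compound 4 (beyond the scatter). Among these compounds, the earlier change on this ring, trifluoromethyl in place of bromo, was seen only with 2,6-dichlorophenyl on the amide-type nitrogen; this step shows a loss beyond the scatter at this ring with 3,5-dimethoxyphenyl on that nitrogen as well, and with the methoxy group gone along with the bromo. No measurement is at hand that bears on the reason for this step.

The change exchanges the whole substitution of the ring at once, so the compounds shown do not separate the loss of bromo, the loss of methoxy and the entry of chloro and fluoro, and no single group can be assigned this step. Also open, from the compounds shown here alone, is whether a ring carrying a dimethylamino group or a carboxylic acid at this nitrogen would hold the number of compound 2, or whether the number would be lower with any ring other than the 5-bromo-2-methoxyphenyl pattern.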